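Aryl sulfide benzamides and cinnamamides: growth inhibition notes

A few compounds are considered here, and "the series" means these few. Any claim that something is new, unique, unknown or untested is made for them only; others in the source may bear on it.

Measured compounds:
compound 1, `Nc1ccccc1NC(=O)/C=C/c1ccc(CSc2ccc(F)cc2)cc1`, 51.2%
compound 2, `Cc1ccc(SCc2ccc(C(=O)Nc3ccccc3N)cc2)cc1`, 40.5%
compound 3, `CC(C)(C)c1ccc(SCc2ccc(/C=C/C(=O)Nc3ccccc3N)cc2)cc1`, 71.5%

In a functional assay on A549 cells (Homo sapiens) for inhibition, read by CCK-8 assay, with a stated time of 72 h, tested at 2 uM (a higher number here means more inhibition of growth at the concentration tested, a lower number less inhibition of growth), compound 2 gives the lowest of the three numbers. Compound 1 stands nearest to it, and compound 3 furthest; both gaps are beyond the scatter, so compound 2 is the weakest of the three measured compounds in this assay.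

The unmeasured compound 4, `Nc1ccccc1NC(=O)c1ccc(CSc2ccc(Cl)cc2)cc1`, differs from compound 2 at the aryl sulfide terminus only: chloro in place of methyl on an aromatic carbon.

Among the measured compounds shown here, no measured step bears on this change directly. For the measured compounds named here, the only one-place step available, a number 20.3 percentage points higher from compound 1 to compound 3 (beyond the scatter), concerns the same position of the sulfur-linked ring but in the core of compound 1, which carries the vinyl spacer absent in compound 2 and compound 4; there the shift from fluoro to tert-butyl moved the number modestly upward. It shows that the substituent on this ring can matter, but it does not say how chloro compares with methyl, and the values of compound 2 against compound 1 and compound 3 mix the spacer with the substituent.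

In this assay the step from compound 2 to compound 4 is therefore expected to be small, a number 3.5 percentage points higher from compound 2 to compound 4 (within the scatter), and compound 4 is estimated at 44%, within 28% to 62%.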

Compound 4, percent growth inhibition at one concentration: 47.3%
Compound 4: middle estimate off by 3.3 percentage points, on the low side; the range from low to high includes it.
By their numbers in this assay, from the lowest: compounds 2, 4 and 1 (each within the scatter of the next, the first and the last beyond it); then compound 3.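

In this assay the exchange on the sulfur-linked ring can now be read directly on the core of compound 2: the step from 4-methylphenyl to 4-chlorophenyl is a number 6.8 percentage points higher from compound 2 to compound 4 (within the scatter) and so does not separate the two compounds. Among the compounds shown here, at this position, methyl and chloro, each a single heavy atom, are therefore not told apart on this core, whereas the only earlier one-place step, a number 20.3 percentage points higher from compound 1 to compound 3 (beyond the scatter) on the core of compound 1, involved fluoro and tert-butyl and stood beyond the scatter. Nothing given here accounts for the size of either step.

The compounds shown leave open whether tert-butyl on the core of compound 2 would bring the same gain as on the core of compound 1, and whether chloro and methyl would also stay within the scatter of each other on the core of compound 1. They also leave open how a methoxy group, an amine or a carboxylic acid at this same place on the ring would read in this assay on either core.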